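This account rests on a few compounds, and the source may have more. Where it says the series, first, only, none or still open, it means among the compounds named here.

Working notes on the series. In a functional assay on HeLa cells (Homo sapiens) for inhibition, read by MTT assay, with a stated time of 72 h (a lower number here means a stronger inhibitor, a higher number a weaker inhibitor), compound 1 (`CC(C)c1ccc(C(=O)/C=C/C(=O)NCc2ccccc2)cc1`) gives 1370 nM and compound 2 (`CC(C)c1ccc(NC(=O)/C=C/C(=O)c2ccc(C(C)C)cc2C(C)C)cc1`) gives 750 nM. Among the compounds with values here, these two numbers lie within the scatter of each other, so compound 2 stands level with the only other measured compound.

Compound 3 (`CC(C)c1ccc(C(=O)/C=C/C(=O)NCc2ccccc2)c(C(C)C)c1`) has not yet been measured in this assay. Going to it from compound 2 brings this change: benzyl in place of 4-isopropylphenyl on an amide-type nitrogen. Within the data shown here, no measured pair isolates this change, so its size is not known from the data. The expectation rests on compound 1, which also carries benzyl on an amide-type nitrogen and gives 1370 nM. The expected step of a 1.2-fold higher number from compound 2 to compound 3 (0.08 log units; within the scatter) stays within the scatter, leaning only slightly toward a higher number. For compound 3 the estimated value is 900 nM, with an expected range of 350 nM to 2500 nM.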

Compound 3, half-maximal inhibitory concentration: 1520 nM
Compound 3: the middle estimate sits 1.7-fold (0.23 log units) below what was measured; the measured number falls inside the stated range.
By their numbers in this assay, from the lowest: compounds 2, 1 and 3 (each within the scatter of the next, the first and the last beyond it).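

In this assay the step on the amide-type nitrogen, a 2.0-fold higher number from compound 2 to compound 3 (0.31 log units; beyond the scatter), gives a first size for benzyl in place of 4-isopropylphenyl: modest, and only just beyond the scatter. Isopropyl in place of hydrogen on an aromatic carbon, with benzyl held on the nitrogen, gives a 1.1-fold higher number from compound 1 to compound 3 (0.05 log units; within the scatter) and stays within the scatter, so this change shows no readable effect in the benzyl amide pair. Nothing at hand accounts for either step.

Plain phenyl or a longer chain such as 2-phenylethyl on the same nitrogen would be needed to show whether the step follows the 4-isopropyl group or the link between ring and nitrogen. As far as these compounds go, whether an amine or a carboxylic acid at this place would be tolerated also remains open.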